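Swapping a Phenyl for a Dimethoxyethyl Chain

The source may report more compounds than this note shows. Statements on the series, on what has been measured and on what is new or still open speak of the compounds shown alone.

Of the compounds shown here, three have so far been tested in a functional assay on NCI-H460 cells (Homo sapiens) for antiproliferative activity, read by CCK-8 assay, with a stated time of 72 h, tested at 2 uM; a higher number here means a stronger effect of the compound at the concentration tested, a lower number a weaker effect. Compound 1 `CC(C)n1cnc2c(Nc3cccc(Cl)c3)nc(NCOCc3ccc(C(=O)Nc4ccccc4N)cc3)nc21` gives 28.9%, compound 2 `Cc1ccc(Nc2nc(Cl)nc3c2ncn3Cc2ccc(/C=C/C(=O)Nc3ccccc3N)cc2)cc1` gives 31.3%, and compound 3 `Nc1ccccc1NC(=O)c1ccc(CNc2nc(Cl)nc3c2ncn3Cc2ccccc2)cc1` gives 43.8%, the highest of the three, standing beyond the usual scatter above both compound 2 and compound 1. Compound 4 `COC(CCn1cnc2c(NCc3ccc(C(=O)Nc4ccccc4N)cc3)nc(Cl)nc21)OC` has not yet been measured. It differs from compound 3 in one place: 2,2-dimethoxyethyl in place of phenyl on a saturated chain carbon bound to an aromatic nitrogen. The phenyl that leaves carries one six-membered aromatic ring of carbon only; the 2,2-dimethoxyethyl that enters has no ring. For the measured compounds named here, no measured pair shows such an exchange, so the expectation rests on this single difference. A moderate fall in inhibition is expected, a number 11.8 percentage points lower from compound 3 to compound 4 (beyond the scatter). Compound 4 is accordingly estimated at 32%, with a likely range from 15% to 48%.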

Compound 4, a percentage reported as inhibition, at one concentration (the size of the read-out at that concentration, not a potency): 43.7%
Beside the measured number, compound 4's estimate is 11.7 percentage points below it, within the range that was stated.
By their numbers in this assay, from the lowest: compounds 1 and 2 (each within the scatter of the next); then compounds 4 and 3 (each within the scatter of the next).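

In this assay the exchange of phenyl for 2,2-dimethoxyethyl on a saturated chain carbon bound to an aromatic nitrogen gives a number 0.1 percentage points lower from compound 3 to compound 4 (within the scatter) and so leaves inhibition unchanged within the scatter. At this position, an aromatic ring is therefore not required to keep this level of inhibition at the single concentration tested, since a group with no ring does as well. No available evidence explains this result. As far as these compounds go, whether an amine, a carboxylic acid or a longer chain would also be tolerated here remains open.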